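The source may report more compounds than this note shows. Statements on the series, on what has been measured and on what is new or still open speak of the compounds shown alone.

Measured compounds:
- compound 1 `O=C(Nc1ccccc1)Nc1cccc(CNc2nccnc2Cl)c1`: 16300 nM
- compound 2 `Cc1ccccc1NC(=O)Nc1cccc(CNc2nccnc2Cl)c1`: 14000 nM

In a functional assay on MGC-803 cells (Homo sapiens) for antiproliferative activity, read by MTT assay, with a stated time of 48 h (on this read-out higher numbers stand for weaker inhibition and lower numbers for stronger inhibition), compound 1 gives 16300 nM, the higher of the two numbers shown; compound 2 gives 14000 nM, and the gap a 1.2-fold lower number from compound 1 to compound 2 (0.07 log units; within the scatter) stays within the scatter.

Compound 3 `CS(=O)(=O)c1ccc(NC(=O)Nc2cccc(CNc3nccnc3Cl)c2)cc1` differs from compound 1 by methylsulfonyl in place of hydrogen on an aromatic carbon. Among the measured compounds shown here, the only measured step, a 1.2-fold lower number from compound 1 to compound 2 (0.07 log units; within the scatter), concerns a different group at a different place and was within the scatter, so nothing here bears directly on a methylsulfonyl. No step beyond the scatter is therefore expected: a 1.1-fold lower number from compound 1 to compound 3 (0.04 log units; within the scatter). For compound 3 in this assay the expected value is 15000 nM, with a range of 5000 nM to 45000 nM.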

Compound 3, half-maximal inhibitory concentration: 12300 nM
Estimate against measurement, compound 3: 1.2-fold (0.09 log units) above; measured number inside the range.
By their numbers in this assay, from the lowest: compounds 3, 2 and 1 (each within the scatter of the next).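

In this assay the position para to a large group, on an aromatic carbon of the six-membered ring, takes methylsulfonyl in place of hydrogen with a step within the scatter (a 1.3-fold lower number from compound 1 to compound 3 (0.12 log units; within the scatter)). Among the compounds shown here, the earlier pair covered only a methyl at a different place, so this is the first reading for a group of 4 heavy atoms with 2 hydrogen-bond acceptors here. Nothing available accounts for this result.

From the compounds shown here alone, whether an amine or a carboxylic acid at this same position would give a step beyond the scatter remains open.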